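The source may report more compounds than this note shows. Statements on the series, on what has been measured and on what is new or still open speak of the compounds shown alone.

Compound 1 `Cc1cc(Nc2cc(-c3ccccc3)[nH]n2)n2nc(SCCc3ccccc3)nc2n1` gives 4930 nM in a functional assay on PC-9 cells (Homo sapiens) for inhibition, read by MTT assay, with a stated time of 72 h; a higher number here means a weaker inhibitor, a lower number a stronger inhibitor. Compound 2 `CCCSc1nc2nc(C)cc(Nc3cc(-c4ccccc4)[nH]n3)n2n1` reaches only the limit of this assay, > 50000 nM, so no exact number is known for it. Among the compounds with values here, the single measured step, an at least 10-fold higher number from compound 1 to compound 2 (1.00 log units; beyond the scatter), ends at the limit of > 50000 nM in this assay, at which 1 of the 2 values shown sits, which fixes where compound 2 stands. Compound 3 `C=CCSc1nc2nc(C)cc(Nc3cc(-c4ccccc4)[nH]n3)n2n1` differs from compound 2 by vinyl in place of ethyl on a saturated chain carbon bound to a sulfur. Within the data shown here, no measured step shows a change of this kind, so the expected shift is small: a number no higher from compound 2 to compound 3 (the limit leaves the size open), within the scatter. Compound 3 is therefore expected to give about 50000 nM, between 15000 nM and 150000 nM, most likely again as a limit.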

Compound 3, half-maximal inhibitory concentration: > 50000 nM
Compound 3 was reported as a limit (the forecaster's own chance of this, stated with the estimate: 70%); the middle value sits exactly at the limit.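

Vinyl in place of benzyl on a saturated chain carbon bound to a sulfur gives an at least 10-fold higher number from compound 1 to compound 3 (1.00 log units; beyond the scatter), so a second small chain on the sulfur also loses the exact reading seen with compound 1. The step from compound 2 to compound 3 cannot be read, so any effect of the new double bond stays hidden at the edge of the measurement: the limit of > 50000 nM in this assay, at which 2 of the 3 values shown sit.

Of the compounds shown, only compound 1 gives an exact number, and it alone has a phenyl ring on the sulfur chain. On these data alone, whether that ring or the chain length matters stays open; a pentyl chain or a cyclohexyl ring in place of the phenyl would bear on this.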